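Quinoline-free notes: cytotoxicity of compound 4 expected from compound 2

This account rests on a few compounds, and the source may have more. Where it says the series, first, only, none or still open, it means among the compounds named here.

Measured so far in an ADME assay on HepG2 cells (Homo sapiens) for cytotoxicity, with a stated time of 72 h; on this read-out lower numbers stand for an effect already at smaller amounts and higher numbers for an effect only at larger amounts of compound:
compound 1 `Cc1cc(NC(=O)Nc2cccc(C(N)=O)c2)c2ccccc2n1`: > 25000 nM, which is a limit of the assay and not a number.
compound 2 `CC(=O)c1ccc(NC(=O)Nc2cc(C)nc3ccccc23)cc1`: 19000 nM.
compound 3 `Cc1cc(NC(=O)Nc2ccc3[nH]cnc3c2)c2ccccc2n1`: > 25000 nM, again a limit of the assay rather than a number.

Going by the values given here, compound 2 therefore stands as the only compound of the three with a true number in this assay; the other two values sit at the limit of > 25000 nM in this assay, at which 2 of the 3 values shown sit. Among the compounds with values here, with only one number and two limits, no step between measured compounds can be given, and the number of compound 2 lies close to the limit at which the others rest.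

Compound 4 `Cc1cc(NC(=O)Nc2ccc(C(F)(F)F)cc2)c2ccccc2n1` differs from compound 2 in one place: trifluoromethyl in place of acetyl on an aromatic carbon. The acetyl that leaves and the trifluoromethyl that enters both sit on the same aromatic carbon, and the shared core is untouched.

For this change the expected step in this assay is a 1.1-fold higher number from compound 2 to compound 4 (0.02 log units; within the scatter), that is, none beyond the usual scatter, in either direction. Compound 4 is thus estimated at 20000 nM, with a range from 8000 nM to 50000 nM, and a sizeable chance that only a limit is reported.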

Compound 4, half-maximal effective concentration: 23000 nM
For compound 4 the middle estimate is 1.2-fold (0.06 log units) below the measured one; measured number inside the range.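

In this assay, going by these compounds alone, trifluoromethyl in place of acetyl on an aromatic carbon, para to a large group, gives the first step that can be read: a 1.2-fold higher number from compound 2 to compound 4 (0.08 log units; within the scatter). Acetyl carries one hydrogen-bond acceptor and one double bond outside aromatic rings, trifluoromethyl carries neither, and compound 2 and compound 4 still cannot be told apart at this position. The series now holds two numbers, while the other values remain limits of the assay: the limit of > 25000 nM in this assay, at which 2 of the 4 values shown sit.

As far as these compounds go, whether an amine or a carboxylic acid on this same aromatic carbon would move the number beyond the scatter remains open, as does the effect of a longer chain there. Steps involving compound 1 or compound 3 cannot be read.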